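Fluorophenyl in place of trifluoromethylphenyl on the chain carbon

The compounds below may be only part of what the source reports. "The series", "measured", "known", "first", "only" and "open" are said of these compounds alone.

Compound 3 `Cc1ccnc(NC(c2ccc(C(F)(F)F)cc2)c2ccc3cccnc3c2O)c1` gives 2100 nM in a functional assay on U-87MG ATCC cells for inhibition, with U-87 MG (Homo sapiens) as the target, read by MTT assay, with a stated time of 72 h; on this read-out lower numbers stand for stronger inhibition and higher numbers for weaker inhibition. That is the lowest of the two numbers seen so far, but compound 1 `Cc1ccnc(NC(c2ccc([N+](=O)[O-])cc2)c2ccc3cccnc3c2O)c1` gives 3400 nM, and the step of a 1.6-fold lower number from compound 1 to compound 3 (0.21 log units; within the scatter) lies within the scatter, so the two cannot be ranked. Compound 2 `Cc1ccnc(NC(c2ccccc2)c2ccc3cccnc3c2O)c1` returns only a limit in this assay, > 10000 nM; this is the limit of > 10000 nM in this assay, at which 1 of the 3 values shown sits.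

Going by the values given here, two steps bear on the next compound. The step of an at least 4.7-fold lower number from compound 2 to compound 3 (0.67 log units; beyond the scatter) and the step of an at least 2.9-fold higher number from compound 1 to compound 2 (0.46 log units; beyond the scatter) both show that the unsubstituted phenyl gives a higher number than either substituted phenyl, beyond the scatter. Compound 4 `Cc1ccnc(NC(c2cccc(F)c2)c2ccc3cccnc3c2O)c1` carries the change (3-fluorophenyl in place of 4-(trifluoromethyl)phenyl on a saturated chain carbon bound to an aromatic carbon and a nitrogen on an aromatic ring). The trifluoromethyl leaves and a single fluorine enters, so compound 4 sits between the substituted and the unsubstituted cases of compounds 3 and 2. The expectation is therefore a modest rise in this assay, a 2.6-fold higher number from compound 3 to compound 4 (0.42 log units; beyond the scatter), short of the limit seen for compound 2. Compound 4 is estimated at 5500 nM, with a range of 2500 nM to 12000 nM.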

Compound 4, half-maximal inhibitory concentration: 9200 nM
Estimate against measurement, compound 4: 1.7-fold (0.22 log units) below, within the range that was stated.
By their numbers in this assay, from the lowest: compounds 3 and 1 (each within the scatter of the next); then compound 4. At a limit, above all of these: compound 2.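

In this assay, 3-fluorophenyl on the saturated chain carbon bound to an aromatic carbon and a nitrogen on an aromatic ring does not keep the level of the two earlier substituted phenyl groups, and both steps are modest: a 4.4-fold higher number from compound 3 to compound 4 (0.64 log units; beyond the scatter) and a 2.7-fold higher number from compound 1 to compound 4 (0.43 log units; beyond the scatter). A substituent on the phenyl therefore does not by itself give the lower numbers of compound 1 and compound 3, and compound 4 goes against any such pattern. Going by these compounds alone, with fluoro in place of hydrogen on an aromatic carbon, the step is an at least 1.0-fold lower number from compound 2 to compound 4 (0.03 log units; that floor lies within the scatter), and this floor gives no order for the pair. Compound 2 stands at a limit of the assay: the limit of > 10000 nM in this assay, at which 1 of the 4 values shown sits.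

Compound 4 differs from compound 3 in both the substituent and its place on the phenyl, and the compounds shown do not separate the two; 4-fluorophenyl and 3-(trifluoromethyl)phenyl would do so. From the compounds shown here alone, how an amine or a carboxylic acid on the phenyl would read here also stays open.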